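The source may hold more compounds than are shown below. What is called first, only, known or untested is meant among the compounds shown, and "the series" means these compounds.

Measured in a functional assay on HeLa cells (Homo sapiens) for antiproliferative activity, read by MTT assay, with a stated time of 72 h; a higher number here means a weaker inhibitor, a lower number a stronger inhibitor:
Compound 1 `COc1cc(-c2ncnn2-c2cccc(F)c2)cc(OC)c1OC`: > 10000 nM
Compound 2 `COc1ccc(-c2ncnn2-c2cc(OC)c(OC)c(OC)c2)cc1`: 280 nM

Compound 1 shows > 10000 nM, which is a limit of the assay, not a number. Among the compounds with values here, compound 2, at 280 nM, therefore holds the only exact value so far, with nothing exact to rank it against. Compound 3 `COc1cccc(-c2ncnn2-c2cc(OC)c(OC)c(OC)c2)c1` has the same atoms as compound 2, joined differently: 3-methoxyphenyl in place of 4-methoxyphenyl on an aromatic carbon. Within the data shown here, no measured step between closely matched compounds shows how much this change matters, so the expectation is tentative: a sizeable loss of activity in this assay. The expected change is an 8.9-fold higher number from compound 2 to compound 3 (0.95 log units; beyond the scatter). For compound 3 the estimated value is 2500 nM, with an expected range of 400 nM to 10000 nM.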

Compound 3, half-maximal inhibitory concentration: > 10000 nM
Compound 3: a limit, no number; the forecaster's own chance of this, stated with the estimate: 25%; middle value at least 4.0-fold (0.60 log units) away from the limit.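

Putting 3-methoxyphenyl in place of 4-methoxyphenyl on an aromatic carbon gives an at least 35-fold higher number from compound 2 to compound 3 (1.55 log units; beyond the scatter) in this assay. With the same atoms joined differently, activity at this place depends on how the methoxy group is attached to the phenyl ring, not only on which atoms are present. The step marks only the smallest possible change, since compound 3 sits at a limit, not a number: the limit of > 10000 nM in this assay, at which 2 of the 3 values shown sit.

Still open, going by these compounds, is whether an amine or a hydroxyl group in place of the methoxy group of 4-methoxyphenyl would keep the activity of compound 2.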